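Shrinking the cycloalkylamine on a xanthine-type adenosine antagonist

This account rests on a few compounds, and the source may have more. Where it says the series, first, only, none or still open, it means among the compounds named here.

Compound 2 `CCCn1c(=O)c2nc(NC3CCCC3)[nH]c2n(CCC)c1=O` gives 8 nM in a functional assay for antagonist activity at adenosine receptor A1 (Homo sapiens) (on this read-out higher numbers stand for weaker inhibition and lower numbers for stronger inhibition), the lower of the two numbers measured; compound 1 `CCCn1c(=O)c2nc(C3CCC3C(=O)O)[nH]c2n(CCC)c1=O` gives 660 nM. Among the measured compounds shown here, the one measured step, an 83-fold lower number from compound 1 to compound 2 (1.92 log units; beyond the scatter), concerns a different change and bears only loosely on the new one. Compound 3 `CCCn1c(=O)c2nc(NC3CCC3)[nH]c2n(CCC)c1=O` differs from compound 2 by cyclobutyl in place of cyclopentyl on a nitrogen on an aromatic ring. For the measured compounds named here, with no step of this kind measured, compound 3 is expected to sit a 3.1-fold higher number from compound 2 to compound 3 (0.49 log units; beyond the scatter), a modest loss in this assay. The estimate for compound 3 is 25 nM, within a range of 6 nM to 100 nM.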

Compound 3, inhibition constant: 2.6 nM
The estimate for compound 3 lay 9.6-fold (0.98 log units) above the measured number; the measured number lies below the stated range.
By their numbers in this assay, from the lowest: compound 3; then compound 2; then compound 1.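

In this assay, the ring on this nitrogen can shrink without a loss: cyclobutyl in place of cyclopentyl on a nitrogen on an aromatic ring gives a gain (a 3.1-fold lower number from compound 2 to compound 3 (0.49 log units; beyond the scatter)), so the smaller ring is the better of the two here. Cyclobutylamino also stands far from 2-carboxycyclobutyl on the shared core (a 250-fold lower number from compound 1 to compound 3 (2.40 log units; beyond the scatter)). Nothing available explains why the smaller ring does better. Still open, on these data alone, is whether cyclopropyl on the same nitrogen would continue this gain, and how an open chain such as isopropyl would compare with the two rings.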